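Methylating a phenol oxygen: cytotoxicity on Vero cells

This account rests on a few compounds, and the source may have more. Where it says the series, first, only, none or still open, it means among the compounds named here.

Measured so far:
compound 1, `O=C(c1ccncc1)N1N=C(c2cc3ccccc3o2)CC1c1ccccc1O`: > 195000 nM (a limit)
compound 2, `COc1ccccc1C1CC(c2cc3ccccc3o2)=NN1C(=O)c1ccncc1`: > 202000 nM (a limit)
compound 3, `CCn1cc(C(=O)N2N=C(c3cc4ccccc4o3)CC2c2ccccc2O)c(=O)c2ccc(C)nc21`: > 157000 nM (a limit)

In an ADME assay on Vero cells (Chlorocebus sabaeus) for cytotoxicity, read by MTT assay, with a stated time of 72 h (a lower number here means a stronger inhibitor, a higher number a weaker inhibitor), compound 1 reaches only the limit of the assay, > 195000 nM. Compound 2 likewise gives no number, only the limit > 202000 nM. Compound 3 also stops at a limit, > 157000 nM. The change from compound 1 to compound 2 is methyl in place of hydrogen on an oxygen on an aromatic ring, and the step it made is a step that the two limits leave unreadable from compound 1 to compound 2, because both values sit at limits the limit of > 195000 nM in this assay, at which 1 of the 3 values shown sits, and (the limit of > 202000 nM in this assay, at which 1 of the 3 values shown sits). The difference between the core of compound 1 and the core of compound 3 is not broken down here.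

Compound 4, `CCn1cc(C(=O)N2N=C(c3cc4ccccc4o3)CC2c2ccccc2OC)c(=O)c2ccc(C)nc21`, carries the same change, (methyl in place of hydrogen on an oxygen on an aromatic ring), on the core of compound 3. Since compound 3 sits at the limit of > 157000 nM in this assay, at which 1 of the 3 values shown sits, and compound 2 at the limit (the limit of > 202000 nM in this assay, at which 1 of the 3 values shown sits), compound 4 is expected to remain at a limit in this assay as well. The step from compound 3 to compound 4 is expected to be a step that the limit leaves unreadable from compound 3 to compound 4. The estimate for compound 4 is 200000 nM, between 100000 nM and 400000 nM.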

Compound 4, half-maximal inhibitory concentration: > 187000 nM
Compound 4: no number, only a limit (the forecaster's own chance of this, stated with the estimate: 85%); the middle value does not contradict the limit.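

In this assay compound 3 gives only a limit, > 157000 nM. Compound 4 also gives only a limit, > 187000 nM. No size can be read for the step between compound 3 and compound 4. The compounds shown leave open how much hydroxy to methoxy changes the result in this assay, as none of compounds 1 to 4 gives an actual number.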